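A few compounds are considered here, and "the series" means these few. Any claim that something is new, unique, unknown or untested is made for them only; others in the source may bear on it.

Compound 1 `Cc1cc(C#N)cc(C)c1Oc1nc(NC2CCC(NS(=O)(=O)c3ccc(C#N)cc3)CC2)nc2ccsc12` and compound 2 `Cc1cc(C#N)cc(C)c1Oc1nc(NC2CCC(NC(=O)c3ccc(F)cc3)CC2)nc2ccsc12` share one core and differ in one place. In an ADME assay on MT4 cells (Homo sapiens) for cytotoxicity, read by MTT assay, with a stated time of 5 days (on this read-out lower numbers stand for higher toxicity in this test and higher numbers for lower toxicity in this test), compound 1 gives 9290 nM, and compound 2 gives 3180 nM. Within the data shown here, the only step on record is a 2.9-fold lower number from compound 1 to compound 2 (0.47 log units; beyond the scatter). Among the measured compounds shown here, compound 2 therefore holds the lower of the two numbers, with compound 1 as its sole neighbour at the higher one.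

Compound 3 `Cc1cc(C#N)cc(C)c1Oc1nc(NC2CCC(NC(=O)c3ccc(Br)cc3)CC2)nc2ccsc12` carries bromo in place of fluoro on an aromatic carbon. For the measured compounds named here, no measured step exchanges one halogen for another on that ring; the single recorded step swapped the whole (4-cyanophenyl)sulfonyl for (4-fluorophenyl)carbonyl, a larger change than this one, and moved the number only modestly. A step no larger than that is therefore expected, most likely within the scatter, with at most a slight lowering. For compound 3 the expected result is 2500 nM (range 1000 nM to 6500 nM), meaning an expected step of a 1.3-fold lower number from compound 2 to compound 3 (0.10 log units; within the scatter).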

Compound 3, half-maximal cytotoxic concentration: 2850 nM
Beside the measured number, compound 3's estimate is 1.1-fold (0.06 log units) below it, within the range that was stated.
By their numbers in this assay, from the lowest: compounds 3 and 2 (each within the scatter of the next); then compound 1.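

Bromo in place of fluoro on this aromatic carbon, para to a large group, gives a 1.1-fold lower number from compound 2 to compound 3 (0.05 log units; within the scatter) in this assay, so compound 2 and compound 3 read alike and this exchange of one halogen for the other registers no difference at this position. The step from the sulfonamide to the bromo amide, a 3.3-fold lower number from compound 1 to compound 3 (0.51 log units; beyond the scatter), lies beyond the scatter, as does a 2.9-fold lower number from compound 1 to compound 2 (0.47 log units; beyond the scatter), so with either halogen the (4-halophenyl)carbonyl compound stands lower than compound 1. No supporting data bear on the reading of this result.

On these data alone, whether an amine, a carboxylic acid or a methoxy group on the same carbon would read like the halogens remains open. So does whether a longer chain between the carbonyl and the aromatic ring would leave the number unchanged.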